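The source may report more compounds than this note shows. Statements on the series, on what has been measured and on what is new or still open speak of the compounds shown alone.

Measured in an ADME assay on Vero cells (Chlorocebus sabaeus) for cytotoxicity, read by MTT assay; on this read-out higher numbers stand for lower toxicity in this test and lower numbers for higher toxicity in this test:

- compound 1 `CCn1nc(C(F)(F)F)cc1C(=O)Nc1ccc(S(=O)(=O)N2CCCCC2C)cc1`: 30000 nM
- compound 2 `Cn1nc(C(F)(F)F)cc1C(=O)Nc1ccc(S(=O)(=O)NC2CCCCC2)cc1`: 15000 nM
- compound 3 `Cn1nc(C(F)(F)F)cc1C(=O)Nc1ccc(S(=O)(=O)N2CCN(C(=O)OC(C)(C)C)CC2)cc1`: > 300000 nM

Only two of these results are actual numbers, and compound 2 at 15000 nM lies within the usual scatter of compound 1 at 30000 nM. For compound 3, > 300000 nM is a limit of the assay and not a number.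

Compound 4 `Cn1nc(C(F)(F)F)cc1C(=O)Nc1ccc(S(=O)(=O)N2CCC(O)CC2)cc1` has not yet been measured in this assay. Compared with compound 2, it carries 4-hydroxypiperidin-1-yl in place of cyclohexylamino on a sulfonyl sulfur. Within the data shown here, no measured pair differs in one place, so the expectation rests on loose comparison alone. A modest step to a higher number is expected, with compound 3 at its limit of > 300000 nM pointing upward. Compound 1 at 30000 nM argues against a large step. The estimated change is a 4.0-fold higher number from compound 2 to compound 4 (0.60 log units; beyond the scatter). For compound 4 the estimated value is 60000 nM, with an expected range from 15000 nM to 250000 nM.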

Compound 4, half-maximal cytotoxic concentration: 274000 nM
Compound 4: middle estimate off by 4.6-fold (0.66 log units), on the low side; the whole stated range lies below it.
By their numbers in this assay, from the lowest: compounds 2 and 1 (each within the scatter of the next); then compound 4. At a limit, above all of these: compound 3.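

In this assay, the group on the sulfonyl sulfur proves to have a strong bearing on the read-out: 4-hydroxypiperidin-1-yl in place of cyclohexylamino gives an 18-fold higher number from compound 2 to compound 4 (1.26 log units; beyond the scatter). This is the first change shown that sits in one place only, so the step can be tied to this position, with the rest of the core the same in both compounds. The change keeps a six-membered non-aromatic ring on the sulfur and puts hetero atoms into it, and that alone moves the number well beyond the scatter.

On these data alone, how far this position can go stays open, as compound 3 gives a limit and not a number: the limit of > 300000 nM in this assay, at which 1 of the 4 values shown sits. Whether the hydroxyl or the ring bound through its nitrogen carries the step is also open, and an unsubstituted piperidin-1-yl or a 4-aminopiperidin-1-yl at this place would bear on that.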